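Dichloro analogue of compound 1: expected growth inhibition

The source may report more compounds than this note shows. Statements on the series, on what has been measured and on what is new or still open speak of the compounds shown alone.

Among the measured compounds shown here, three benzyl-substituted purine-type compounds have numbers so far in a functional assay on K562 cells (Homo sapiens) for cytotoxicity, read by sulforhodamine B assay, with a stated time of 48 h; a lower number here means a stronger inhibitor of growth, a higher number a weaker inhibitor of growth. Compound 1 `ClCc1cccc(Cn2cnc3ncnc(Cl)c32)c1` gives 16600 nM. Compound 2 `ClCc1cccc(Cn2cnc3c(Cl)ncnc32)c1` gives 3540 nM, a lower number than compound 1 and beyond the scatter. Compound 3 `ClCc1ccc(Cn2cnc3c(Cl)nc(Cl)nc32)cc1` gives 23400 nM, which sits within the scatter of compound 1. Compound 1 therefore stands second highest of the three numbers, close to compound 3 and well apart from compound 2.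

Compound 4 `ClCc1cccc(Cn2cnc3nc(Cl)nc(Cl)c32)c1` is not yet measured. It differs from compound 1 by chloro in place of hydrogen on an aromatic carbon. For the measured compounds named here, no single-change pair among the measured compounds reproduces this change, so its size is unknown from the data. Compound 3, which also carries two chloro groups on its core, gives a number within the scatter of compound 1, which argues against a large shift in either direction. The step from compound 1 to compound 4 is expected to be a 1.1-fold higher number from compound 1 to compound 4 (0.04 log units; within the scatter), not beyond the scatter. Compound 4 is estimated at 18000 nM in this assay, with a range from 7000 nM to 45000 nM.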

Compound 4, concentration for 50% growth inhibition: 1410 nM
Estimate against measurement, compound 4: 13-fold (1.11 log units) above; measured number below the stated range.
By their numbers in this assay, from the lowest: compound 4; then compound 2; then compounds 1 and 3 (each within the scatter of the next).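

In this assay, chloro in place of hydrogen on the aromatic carbon between two ring nitrogen atoms gives a 12-fold lower number from compound 1 to compound 4 (1.07 log units; beyond the scatter), a large step. Among the compounds shown here, this is the first change that can be read in one place, as no two earlier compounds differed in only one place. It shows that this carbon is not a silent position on the core of compound 1, and that a single chlorine there is enough to move the number well beyond the scatter. Nothing measured here accounts for the size of this step.

As far as these compounds go, it remains open whether the step is specific to chloro, since a methyl group, an amine or a methoxy group on the same carbon would test that. From the compounds shown here alone, it also remains open whether the same change would give a step of similar size on the core of compound 2.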